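Ethoxy on the Phenyl Ring: Cytotoxicity Expected to Stay Low

The source may report more compounds than this note shows. Statements on the series, on what has been measured and on what is new or still open speak of the compounds shown alone.

Compound 2 `CCOC(=O)c1c(-c2ccccc2)[nH]c2cc(OC)ccc2c1=O` has been tested in an ADME assay on HepG2 cells (Homo sapiens) for cytotoxicity, read by luminescence, with a stated time of 72 h; on this read-out higher numbers stand for an effect only at larger amounts of compound and lower numbers for an effect already at smaller amounts. In this assay compound 2 reaches only a limit, > 21500 nM. Compound 1 `CCOC(=O)c1c(-c2cc(F)cc(OC)c2)[nH]c2cc(OC)ccc2c1=O` likewise gives a limit, > 21500 nM. Compound 3 `C=Cc1cccc(-c2[nH]c3cc(OC)ccc3c(=O)c2C(=O)OCC)c1` also ends at a limit, > 21500 nM. The steps a step that the two limits leave unreadable from compound 1 to compound 2, a step that the two limits leave unreadable from compound 1 to compound 3 and a step that the two limits leave unreadable from compound 2 to compound 3 therefore cannot be read, a consequence of the limit of > 21500 nM in this assay, at which 3 of the 3 values shown sit. Compound 4 `CCOC(=O)c1c(-c2cccc(OCC)c2)[nH]c2cc(OC)ccc2c1=O` carries ethoxy in place of hydrogen on an aromatic carbon. For the measured compounds named here, no measured step bears directly on this change, and none of the measured steps has a readable size. The expectation is that compound 4 shows no step beyond the scatter, an expected step that the limit leaves unreadable from compound 2 to compound 4, and that this assay most probably returns a limit once more. Compound 4 is estimated at 30000 nM, within 15000 nM to 90000 nM.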

Compound 4, half-maximal effective concentration: > 21500 nM
Compound 4: a limit, no number; the forecaster's own chance of this, stated with the estimate: 85%; the middle value is on the limit's open side.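

In this assay compound 4 gives only a limit, > 21500 nM, and no step from compound 1, compound 2 or compound 3 to compound 4 can be read: the limit of > 21500 nM in this assay, at which 4 of the 4 values shown sit.

The compounds shown leave open whether the changes on the phenyl ring alter cytotoxicity at all.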